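Compound 4 on the scale of Vero cell toxicity

A few compounds are considered here, and "the series" means these few. Any claim that something is new, unique, unknown or untested is made for them only; others in the source may bear on it.

- Compound 1 `CC(C)(C)c1ccc(C(=O)/C=C/c2ccc([N+](=O)[O-])o2)cc1`: > 100000 nM (a limit)
- Compound 2 `Cc1ccccc1C(=O)/C=C/c1ccc([N+](=O)[O-])o1`: 41300 nM
- Compound 3 `O=C(/C=C/c1ccc([N+](=O)[O-])o1)c1ccc(-c2ccccc2)cc1`: > 100000 nM (a limit)

In an ADME assay on Vero cells (Chlorocebus sabaeus) for cytotoxicity, read by resazurin assay, with a stated time of 72 h (on this read-out higher numbers stand for lower toxicity in this test and lower numbers for higher toxicity in this test), compound 3 gives > 100000 nM, which is a limit and not a number. This is the limit of > 100000 nM in this assay, at which 2 of the 3 values shown sit. Compound 4 `O=C(/C=C/c1ccc([N+](=O)[O-])o1)c1ccc(N2CCNCC2)cc1` carries piperazin-1-yl in place of phenyl on an aromatic carbon, para to a large group (piperazin-1-yl in place of phenyl on an aromatic carbon). Within the data shown here, the one measured step at this place is a step that the two limits leave unreadable from compound 1 to compound 3, so it offers no size to carry over. Compound 2 gives 41300 nM, which shows that the shared core can yield a number in this assay. A move towards lower numbers, meaning higher toxicity, is therefore expected, and the estimated step is an at least 2.2-fold lower number from compound 3 to compound 4 (0.34 log units; beyond the scatter). For compound 4 the estimated value is 45000 nM, with an expected range from 12000 nM to 100000 nM.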

Compound 4, half-maximal cytotoxic concentration: > 100000 nM
Compound 4 gave a limit, no number; the forecaster's own chance of this, stated with the estimate: 35%; at least 2.2-fold (0.34 log units) between middle value and limit.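

In this assay compound 4 gives > 100000 nM, which is a limit. Among these compounds, compound 1, compound 3 and compound 4 all end at limits, so no step among them can be read. The compounds shown leave open whether tert-butyl, phenyl and piperazin-1-yl differ at all in this test: the limit of > 100000 nM in this assay, at which 3 of the 4 values shown sit.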